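This account rests on a few compounds, and the source may have more. Where it says the series, first, only, none or still open, it means among the compounds named here.

Compound 2 `c1cn2cc(-c3ccsc3)nc(-c3ccc4ncn(C5CCCCC5)c4c3)c2n1` gives 5.68% in a functional assay on HT-29 cells (Homo sapiens) for inhibition, read by sulforhodamine B assay, with a stated time of 48 h, tested at 10 uM (a higher number here means more inhibition at the concentration tested (going by the name of the read-out), a lower number less inhibition), the lowest of the two numbers available; compound 1 `COc1ccc(-c2cn3ccnc3c(-c3ccc4ncn(C5CCCCC5)c4c3)n2)cc1` gives 92.5%. Compound 3 `COc1ccccc1-c1cn2ccnc2c(-c2ccc3ncn(C4CCCCC4)c3c2)n1` is not yet measured. It differs from compound 2 in one place: 2-methoxyphenyl in place of thiophen-3-yl on an aromatic carbon. For the measured compounds named here, one measured step bears on this, the change a number 86.8 percentage points lower from compound 1 to compound 2 (beyond the scatter), in which the methoxyphenyl group left and the thiophen-3-yl group entered. Compound 3 brings a methoxyphenyl group back, although with the methoxy group in a different spot, so a large rise is expected, roughly a number 54.3 percentage points higher from compound 2 to compound 3 (beyond the scatter). Compound 3 is therefore estimated at 60%, with a range from 20% to 93%.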

Compound 3, a percentage reported as inhibition, at one concentration (the size of the read-out at that concentration, not a potency): 11.1%
Compound 3: the middle estimate sits 48.9 percentage points above what was measured, outside the stated range (below it).
By their numbers in this assay, from the lowest: compounds 2 and 3 (each within the scatter of the next); then compound 1.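

In this assay, having a methoxyphenyl group at this position is not enough: 2-methoxyphenyl in place of 4-methoxyphenyl gives a number 81.4 percentage points lower from compound 1 to compound 3 (beyond the scatter). Replacing thiophen-3-yl with 2-methoxyphenyl gives a number 5.4 percentage points higher from compound 2 to compound 3 (within the scatter), so these two groups cannot be told apart here, and the methoxy group's spot on the phenyl ring separates compound 1 from compound 3. Nothing available explains this difference. Still open, as far as these compounds go, is whether an amine, a carboxylic acid or a longer chain in place of the methoxy group of compound 1 would retain the high inhibition.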